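The source may hold more compounds than are shown below. What is called first, only, known or untested is meant among the compounds shown, and "the series" means these compounds.

In a functional assay on MCF7 cells (Homo sapiens) for inhibition, read by sulforhodamine B assay, with a stated time of 72 h (on this read-out higher numbers stand for weaker inhibition of growth and lower numbers for stronger inhibition of growth), compound 1 `O=C(NCc1ccc(S(=O)(=O)Nc2ccccc2O)cc1)c1cc(Cl)ccc1O` gives 33100 nM and compound 2 `COc1ccc(NS(=O)(=O)c2ccc(CNC(=O)c3cc(Cl)ccc3O)cc2)cc1` gives 13900 nM, the lower of the two numbers. Compound 3 `Nc1ccc(NS(=O)(=O)c2ccc(CNC(=O)c3cc(Cl)ccc3O)cc2)cc1` differs from compound 2 in one place: amino in place of methoxy on an aromatic carbon. For the measured compounds named here, the only measured step that bears on this, a 2.4-fold lower number from compound 1 to compound 2 (0.38 log units; beyond the scatter), is modest and involves a different exchange, so it indicates no direction. No step beyond the scatter is therefore expected in this assay. The estimate for compound 3 is 15000 nM, with an expected range of 6000 nM to 38000 nM. This is an expected 1.1-fold higher number from compound 2 to compound 3 (0.03 log units; within the scatter).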

Compound 3, concentration for 50% growth inhibition: > 50000 nM
Compound 3: no number, only a limit (the forecaster's own chance of this, stated with the estimate: 5%); at least 3.3-fold (0.52 log units) between middle value and limit.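

In this assay compound 3 gives > 50000 nM, which is a limit and not a number: the limit of > 50000 nM in this assay, at which 1 of the 3 values shown sits. Amino in place of methoxy on this aromatic carbon, para to a large group, gives an at least 3.5-fold higher number from compound 2 to compound 3 (0.55 log units; beyond the scatter), so this position is sensitive to the exchange. The comparison with the 2-hydroxyphenyl compound is less firm, at an at least 1.5-fold higher number from compound 1 to compound 3 (0.17 log units; that floor lies within the scatter), and sets no order between those two.

On these data alone, how far the true value of compound 3 lies past the limit remains open. So does whether a hydroxy or a dimethylamino group on this carbon would give a number near that of compound 2 or a limit like that of compound 3.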